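The compounds below may be only part of what the source reports. "The series", "measured", "known", "first", "only" and "open" are said of these compounds alone.

Of the compounds shown here, three have numbers so far in a functional assay on HepG2 cells (Homo sapiens) for antiproliferative activity, read by MTT assay, with a stated time of 24 h (on this read-out lower numbers stand for stronger inhibition and higher numbers for weaker inhibition), on the same kind of scaffold. Compound 1 (`O=S(=O)(c1ccc(Br)cc1)n1c(-c2cn(-c3ccccc3)nc2-c2ccc(F)cc2)nc2ccccc21`) gives 2550 nM on this read-out, compound 2 (`O=S(=O)(c1ccccc1)n1c(-c2cn(-c3ccccc3)nc2-c2ccc(C(F)(F)F)cc2)nc2ccccc21`) gives 590 nM and compound 3 (`Cc1ccc(C)c(S(=O)(=O)n2c(-c3cn(-c4ccccc4)nc3-c3ccc(C(F)(F)F)cc3)nc3ccccc32)c1`) gives 330 nM as its value. Compound 3 therefore sits level with compound 2 within the scatter and well under compound 1. Compound 4 (`O=S(=O)(c1ccc(Br)cc1)n1c(-c2cn(-c3ccccc3)nc2-c2ccc(C(F)(F)F)cc2)nc2ccccc21`) carries one change from compound 3 (4-bromophenyl in place of 2,5-dimethylphenyl on a sulfonyl sulfur), namely 4-bromophenyl in place of 2,5-dimethylphenyl on a sulfonyl sulfur. The closest measured step, phenyl to 2,5-dimethylphenyl on the same sulfur, shows a 1.8-fold lower number from compound 2 to compound 3 (0.25 log units; within the scatter) and so offers no large effect to carry over. Compound 4 differs elsewhere from compound 1, which carries the same 4-bromophenyl and gives 2550 nM as its value, so that number only tilts the expectation toward weaker inhibition. In this assay the expected step is a 1.8-fold higher number from compound 3 to compound 4 (0.26 log units; within the scatter) and no larger. For compound 4 the estimated value is 600 nM with an expected range from 250 nM to 1500 nM around it.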

Compound 4, half-maximal inhibitory concentration: 2160 nM
Beside the measured number, compound 4's estimate is 3.6-fold (0.56 log units) below it; measured number outside the range, above it.
By their numbers in this assay, from the lowest: compounds 3 and 2 (each within the scatter of the next); then compounds 4 and 1 (each within the scatter of the next).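

On the sulfonyl sulfur, the aryl group matters more than the earlier pair suggested: in this assay, 4-bromophenyl in place of 2,5-dimethylphenyl weakens inhibition beyond the scatter (a 6.5-fold higher number from compound 3 to compound 4 (0.82 log units; beyond the scatter)), and bromo in place of hydrogen on the plain phenyl alone does so as well (a 3.7-fold higher number from compound 2 to compound 4 (0.56 log units; beyond the scatter)). Trifluoromethyl in place of fluoro on an aromatic carbon leaves the bromo compounds within the scatter of each other (a 1.2-fold lower number from compound 1 to compound 4 (0.07 log units; within the scatter)), so the high number of compound 1 fits the bromo group and not only the fluoro. Nothing measured here explains why the bromo group weakens inhibition.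

A chloro, a methoxy or an amine in place of the bromo would show whether the weaker inhibition follows bromine alone or any such group. Also open, from the compounds shown here alone, is how a sulfonyl sulfur carrying a short alkyl chain instead of an aromatic ring would behave.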